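Bromo to Dimethylamino: Estimating the Solubility of Compound 4

The compounds below may be only part of what the source reports. "The series", "measured", "known", "first", "only" and "open" are said of these compounds alone.

Of the compounds shown here, three have been measured in a physicochemical assay for solubility, using the shake flask method, in simulated intestinal fluid, measured as kinetic solubility, with a stated time of 2 h, at 25 degrees C, at pH 6.5; on this read-out lower numbers stand for lower solubility and higher numbers for higher solubility. Compound 1, `Cc1nc(C(=O)OC2CC2)c(N)c2c1C(=O)N(Cc1ccccc1)C2=O`, gives 202000 nM in this assay. Compound 2, `Cc1nc(C(N)=O)c(N)c2c1C(=O)N(Cc1ccccc1)C2=O`, gives in this assay only a limit of the assay, < 5000 nM. The step of an at least 40-fold lower number from compound 1 to compound 2 (1.60 log units; beyond the scatter) is thus a large fall. Compound 3, `Cc1noc(-c2nc(C)c3c(c2N)C(=O)N(Cc2ccc(Br)cc2)C3=O)n1`, likewise gives in this assay only a limit, < 5000 nM. Compound 3 therefore stands at the lower edge of what this assay can report, the position described by the limit of < 5000 nM in this assay, at which 2 of the 3 values shown sit, and only compound 1 reads as a measured number.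

The unmeasured compound 4 is `Cc1noc(-c2nc(C)c3c(c2N)C(=O)N(Cc2ccc(N(C)C)cc2)C3=O)n1`. It differs from compound 3 in one place: dimethylamino in place of bromo on an aromatic carbon. Going by the values given here, the single measured step concerns a change on a carbonyl carbon and does not cover this change, so there is no direct guide to its size or direction. Because compound 3 sits at the limit < 5000 nM, any true value for compound 4 at or below that limit would again appear only as a limit.

Compound 4 is expected to give about 8000 nM in this assay, within a range from 2000 nM to 40000 nM. The step from compound 3 that this estimate implies is expected to be an at least 1.6-fold higher number from compound 3 to compound 4 (0.20 log units; that floor lies within the scatter).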

Compound 4, solubility: 7400 nM
Compound 4: the middle estimate sits 1.1-fold (0.03 log units) above what was measured, and the stated range covers the measured number.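

Among the compounds shown, compound 4 is the only one with the core of compound 3 that reads as a real number in this assay, so this position, an aromatic carbon para to a large group, can now be followed past the edge of what the assay reports. Dimethylamino in place of bromo gives an at least 1.4-fold higher number from compound 3 to compound 4 (0.17 log units; that floor lies within the scatter), which is only a floor: the real step may be larger, but the smallest step allowed could not be told apart from ordinary repeat-to-repeat variation. Compound 3 remains a limit and not a number, a position it shares with compound 2: the limit of < 5000 nM in this assay, at which 2 of the 4 values shown sit.

As far as these compounds go, how large the step truly is stays open, and so does whether it belongs to dimethylamino in particular or would also appear with other groups on this aromatic carbon. A morpholine ring, a methoxy group or a carboxylic acid at this place would help to separate those two readings, and the compounds shown do not say how any of them would behave.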